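The compounds below may be only part of what the source reports. "The series", "measured", "known", "first", "only" and "open" are said of these compounds alone.

Measured in a functional assay on EOL1 cells (Homo sapiens) for inhibition, read by fluorescence, with a stated time of 72 h; on this read-out higher numbers stand for weaker inhibition of growth and lower numbers for stronger inhibition of growth:
- compound 1 `COc1ccc(Nc2nc(N[C@H]3CC[C@H](N)CC3)nc3c2ncn3CCC(C)C)c(OC)c1`: 630 nM
- compound 2 `CCCCn1cnc2c(Nc3cc(OC)cc(OC)c3)nc(N[C@H]3CC[C@H](N)CC3)nc21`: 370 nM

Compound 1 at 630 nM and compound 2 at 370 nM lie within the usual scatter of each other, so the two cannot be ranked. Compound 3 `CC(C)CCn1cnc2c(Nc3ccccc3)nc(N[C@H]3CC[C@H](N)CC3)nc21` is compound 1 with phenyl in place of 2,4-dimethoxyphenyl on a nitrogen on an aromatic ring. Among the measured compounds shown here, no measured pair isolates this change, so the expectation for this assay is loose. The expected step of a 1.3-fold higher number from compound 1 to compound 3 (0.10 log units; within the scatter) is small, towards a slightly higher number, and may stay within the scatter. For compound 3 the estimated value is 800 nM, with a range of 250 nM to 2500 nM.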

Compound 3, concentration for 50% growth inhibition: 10 nM
For compound 3 the middle estimate is 80-fold (1.90 log units) above the measured one, outside the stated range (below it).
By their numbers in this assay, from the lowest: compound 3; then compounds 2 and 1 (each within the scatter of the next).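

Going from 2,4-dimethoxyphenyl to phenyl in this assay brings a 63-fold lower number from compound 1 to compound 3 (1.80 log units; beyond the scatter) and thus a large change. The group on this nitrogen can therefore strongly affect the growth read-out, something the two earlier compounds could not show, as they differ from each other in more than one place. Nothing measured here explains the step.

On these data alone, it remains open whether one methoxy group alone would give a number near that of compound 1 or compound 3. A fluorine or a hydroxyl on the phenyl also remains to be placed against these values.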